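Phenyl for Cyclobutyl: What Solubility Might Follow

The compounds below may be only part of what the source reports. "The series", "measured", "known", "first", "only" and "open" are said of these compounds alone.

Measured compounds:
Compound 1 `CN1CCC(C(=O)N2Cc3c(NC(=O)C4CCC4)n[nH]c3C2(C)C)CC1` gives > 225000 nM.
Compound 2 `CCN1CCC(C(=O)N2Cc3c(NC(=O)CC(C)C)n[nH]c3C2(C)C)CC1` gives > 225000 nM.

Both values come from a physicochemical assay for solubility, at pH 7; a higher number here means a more soluble compound, a lower number a less soluble compound. The value of compound 1 is a limit of the assay, not a number; the measurement ran out before a value could be read. The same holds for compound 2, and so the limit of > 225000 nM in this assay, at which 2 of the 2 values shown sit, describes where every measured value sits. Between compound 1 and compound 2 no single step is defined, since they differ in more than one place, so all that can be said is that both reach the limit.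

The compound still to be tested is compound 3 `CN1CCC(C(=O)N2Cc3c(NC(=O)c4ccccc4)n[nH]c3C2(C)C)CC1`. It differs from compound 1 in one place: phenyl in place of cyclobutyl on a carbonyl carbon.

For the measured compounds named here, with both measured compounds sitting at the limit, there is no measured step on which to lean, only the change itself. A modest drop in this assay is expected, so the step of an at least 1.8-fold lower number from compound 1 to compound 3 (0.27 log units; that floor lies within the scatter) is estimated as downward but not large. Compound 3 is therefore expected at about 120000 nM, within a range from 30000 nM to 225000 nM.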

Compound 3, solubility: > 225000 nM
Compound 3: a limit, no number (the forecaster's own chance of this, stated with the estimate: 45%); middle value at least 1.8-fold (0.27 log units) away from the limit.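

Compound 1 and compound 3 both end at a limit and not at a number in this assay, so no step between them can be read, and the same limit holds for all the compounds shown: the limit of > 225000 nM in this assay, at which 3 of the 3 values shown sit.

Going by these compounds, how far the solubility of each compound lies past that limit, and whether phenyl or cyclobutyl gives the higher number, stays open.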